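A few compounds are considered here, and "the series" means these few. Any claim that something is new, unique, unknown or untested is made for them only; others in the source may bear on it.

Measured in a functional assay on HCT-116 cells (Homo sapiens) for antiproliferative activity, with a stated time of 72 h; on this read-out higher numbers stand for weaker inhibition and lower numbers for stronger inhibition:
- Compound 1 `COc1cc(OCC(=O)NO)ccc1CNCCn1cnc2ccccc21`: > 10000 nM
- Compound 2 `O=C(COc1ccc(CN2CC=C(c3c[nH]c4cccc(F)c34)CC2)c(F)c1)NO`: 1220 nM

Compound 1 has no exact number on this read-out, and its entry is a limit of this assay. Compound 3 `O=C(COc1ccc(CNCCn2cnc3ccccc32)c(F)c1)NO` is still unmeasured. It differs from compound 1 by having fluoro in place of methoxy on an aromatic carbon, ortho to a large group and meta to a (hydroxycarbamoyl)methoxy group (fluoro in place of methoxy on an aromatic carbon). For the measured compounds named here, no measured step shows what this exchange does, so the expectation is cautious, and compound 3 may also end up at the limit. The estimated step of an at least 1.4-fold lower number from compound 1 to compound 3 (0.15 log units; that floor lies within the scatter) leans modestly towards stronger inhibition. Compound 3 is expected near 7000 nM, with an estimated range of 2000 nM to 20000 nM.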

Compound 3, half-maximal inhibitory concentration: 410 nM
For compound 3 the middle estimate is 17-fold (1.23 log units) above the measured one; measured number below the stated range.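

In this assay, fluoro in place of methoxy on this aromatic carbon, ortho to a large group, gives an at least 24-fold lower number from compound 1 to compound 3 (1.38 log units; beyond the scatter). This position is therefore far from indifferent: one small exchange moves the compound from a limit to an exact number. That step is only a floor, and the real difference may be larger: the limit of > 10000 nM in this assay, at which 1 of the 3 values shown sits.

As far as these compounds go, what stays open is whether the change follows from fluoro entering or from methoxy leaving. A plain hydrogen, a chloro or a methyl group on this carbon would help separate the two.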